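Shortening the ring-nitrogen substituent of compound 1

A few compounds are considered here, and "the series" means these few. Any claim that something is new, unique, unknown or untested is made for them only; others in the source may bear on it.

Going by the values given here, compound 1 `COc1cc2c(cc1OC)CN(C(=O)CN1C(=O)S/C(=C\c3nc4ccccc4n3C(C)C)C1=O)CC2` is measured in a functional assay on A549 cells (Homo sapiens) for inhibition, read by MTT assay, with a stated time of 48 h (a higher number here means a weaker inhibitor, a lower number a stronger inhibitor), at 20600 nM, the lowest of the two numbers read so far. Compound 3 `CCn1c(/C=C2\SC(=O)N(CC(=O)N3CCCC3)C2=O)nc2ccccc21` gives 31200 nM in this assay, and its gap from compound 1 stays within the scatter. Compound 2 `Cn1c(/C=C2\SC(=O)N(CC(=O)N3CCCC3)C2=O)nc2ccccc21` gives > 50000 nM in this assay, which is a limit of the assay and not a number. One of the three values therefore sits at the limit of > 50000 nM in this assay, at which 1 of the 3 values shown sits.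

Among the compounds with values here, the only step between measured compounds that differ in one place is an at least 1.6-fold lower number from compound 2 to compound 3 (0.20 log units; that floor lies within the scatter): lengthening the chain on the ring nitrogen by one carbon lowers the number, though only at a floor that lies within the scatter.

Compound 4 `COc1cc2c(cc1OC)CN(C(=O)CN1C(=O)S/C(=C\c3nc4ccccc4n3C)C1=O)CC2` is not yet measured. Its change from compound 1 is methyl in place of isopropyl on an aromatic nitrogen. This runs opposite to the lengthening seen above, so the step of an at least 1.6-fold lower number from compound 2 to compound 3 (0.20 log units; that floor lies within the scatter) suggests that shortening should raise the number, if anything. Compound 4 is thus expected to move by a 2.0-fold higher number from compound 1 to compound 4 (0.31 log units; beyond the scatter). The estimate for compound 4 is 42000 nM, in the range 18000 nM to 100000 nM, with a real chance that this assay reports only a limit.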

Compound 4, half-maximal inhibitory concentration: 13400 nM
For compound 4 the middle estimate is 3.1-fold (0.50 log units) above the measured one; the whole stated range lies above it.
By their numbers in this assay, from the lowest: compounds 4, 1 and 3 (each within the scatter of the next, the first and the last beyond it). At a limit, above all of these: compound 2.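

Going by these compounds alone, on the aromatic nitrogen, methyl in place of isopropyl gives a 1.5-fold lower number from compound 1 to compound 4 (0.19 log units; within the scatter) in this assay, the first step at this position read between two measured numbers. This change therefore stays within the scatter, and the rise suggested by the earlier step on the same nitrogen does not appear with the amide of compound 1. Compound 2 is a limit of the assay and not a number, so that earlier step offers only a floor: the limit of > 50000 nM in this assay, at which 1 of the 4 values shown sits.

The compounds shown leave open how a longer chain such as butyl, or a chain ending in an amine, would read on this aromatic nitrogen. They also leave open whether any group there can move the number beyond the scatter while the amide of compound 1 stays fixed.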